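The source may report more compounds than this note shows. Statements on the series, on what has been measured and on what is new or still open speak of the compounds shown alone.

Series notes. Compound 1 `CCC(=O)N1CCC(c2cc(OC)ccc2N)=N1` and compound 2 `CCCC(=O)N1CCC(c2cc(OC)ccc2N)=N1` share one core; compound 3 `CC(=O)N1CCC(c2cc(Cl)ccc2N)=N1` and compound 4 `CCC(=O)N1CCC(c2cc(Cl)ccc2N)=N1` share another. The difference between the two cores is not broken down here. In an assay on isolated protein for inhibition of Nitric oxide synthase, inducible (Homo sapiens), with a stated time of 30 min, tested at 1 mM (a higher number here means more inhibition at the concentration tested (going by the name of the read-out), a lower number less inhibition), compound 1 gives 20.4%, and compound 2 gives 13.1%. The step of a number 7.3 percentage points lower from compound 1 to compound 2 (within the scatter) is within the scatter, so these two values are not ordered. The change behind it is methyl in place of hydrogen on a saturated chain carbon, two bonds along the chain from a carbonyl carbon. In this assay compound 3 gives 1.03%, the lowest of the three numbers and beyond the scatter from both others.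

Compound 4 is not yet measured in this assay. Its change from compound 3 is methyl in place of hydrogen on a saturated chain carbon bound to a carbonyl carbon. Within the data shown here, this is the same kind of change as the one from compound 1 to compound 2, not the same: there the place is a saturated chain carbon two bonds along the chain from a carbonyl carbon, here a saturated chain carbon bound to a carbonyl carbon. Among the measured compounds shown here, the one measured instance of this kind of change, a number 7.3 percentage points lower from compound 1 to compound 2 (within the scatter), stayed within the scatter. A small step of a number 2 percentage points higher from compound 3 to compound 4 (within the scatter) is therefore expected, resting on that measured step and on the low starting point, because compound 3 gives 1.03%. Compound 4 is expected to give about 3%, likely between 0% and 12%.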

Compound 4, a percentage reported as inhibition, at one concentration (the size of the read-out at that concentration, not a potency): 13.7%
Estimate against measurement, compound 4: 10.7 percentage points below; measured number outside the range, above it.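

In this assay the step of a number 12.7 percentage points higher from compound 3 to compound 4 (beyond the scatter) goes with acetyl to propanoyl, and the added methyl does not carry over as one fixed step between the two cores: the same change on two cores in this assay, a number 7.3 percentage points lower (within the scatter) from compound 1 to compound 2 and a number 12.7 percentage points higher (beyond the scatter) from compound 3 to compound 4, 20 percentage points apart, beyond the scatter of two such steps

This does not separate the core from the place, as the methyl sits on a saturated chain carbon bound to a carbonyl carbon in one step and two bonds along the chain from a carbonyl carbon in the other, and two instances give no general rule for the series. The step of a number 6.7 percentage points lower from compound 1 to compound 4 (within the scatter), chloro in place of methoxy on an aromatic carbon, leaves compound 1 and compound 4 unordered, and it does not tell how that exchange behaves with other chains.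

Open, on these data alone, is whether a butanoyl group on the core of compound 3 would follow the step seen on the core of compound 1, which would compare the same change at the same place on both cores. Also open, as far as these compounds go, are longer chains on either core and an amine or a carboxylic acid in place of the chloro.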